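The source may hold more compounds than are shown below. What is called first, only, known or untested is meant among the compounds shown, and "the series" means these compounds.

Measured in a functional assay on HCT-116 cells (Homo sapiens) for cytotoxicity, read by MTT assay, with a stated time of 72 h; on this read-out higher numbers stand for weaker inhibition and lower numbers for stronger inhibition:
- compound 1 `COc1ccc(CNC(=O)c2nc(Br)c3cccnc3c2N[C@H]2CC[C@H](N)CC2)cc1` gives 3000 nM
- compound 2 `C[C@H](NC(=O)c1nc(Br)c2cccnc2c1N[C@H]1CC[C@H](N)CC1)c1ccc(F)cc1` gives > 10000 nM (a limit of the assay)
- compound 3 `COC(=O)c1nc(Br)c2cccnc2c1N[C@H]1CC[C@H](N)CC1` gives "not determined" (no result reported)

Among the measured compounds shown here, compound 3 has no number in this assay, so no step can be counted from it. Compound 4 `N[C@H]1CC[C@H](Nc2c(C(=O)Nc3ccccc3)nc(Br)c3cccnc23)CC1` carries anilino in place of methoxy on a carbonyl carbon, with anilino in place of methoxy on a carbonyl carbon. For the measured compounds named here, the only measured step is an at least 3.3-fold higher number from compound 1 to compound 2 (0.52 log units; beyond the scatter). It lies beyond the scatter and changes the group on an amide-type nitrogen, so it bears only indirectly. No step size or direction from compound 3 can be expected. The expectation for the amide compound 4 rests instead on compound 1 at 3000 nM. It rests also on compound 2, which gives > 10000 nM, a limit of the assay. Compound 4 is estimated at 5000 nM, with an expected range of 1500 nM to 10000 nM.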

Compound 4, half-maximal inhibitory concentration: 2000 nM
Compound 4: the middle estimate sits 2.5-fold (0.40 log units) above what was measured; low and high end bracket the measured number.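

In this assay, phenyl in place of 4-methoxybenzyl on the amide-type nitrogen gives a 1.5-fold lower number from compound 1 to compound 4 (0.18 log units; within the scatter), so these two amides cannot be told apart. Phenyl in place of 1-(4-fluorophenyl)ethyl gives an at least 5.0-fold lower number from compound 2 to compound 4 (0.69 log units; beyond the scatter), so among these three amides only 1-(4-fluorophenyl)ethyl stands apart. The value of compound 2 is a limit, not a number: the limit of > 10000 nM in this assay, at which 1 of the 4 values shown sits.

On these data alone, the steps from compound 3 cannot be read, so the effect of anilino in place of methoxy on the carbonyl carbon stays open. Also open, as far as these compounds go, is how a carboxylic acid at that carbonyl carbon, or a 2-phenylethyl chain on the amide nitrogen, would read.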